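A second fluoro on compound 3

The source may report more compounds than this note shows. Statements on the series, on what has been measured and on what is new or still open speak of the compounds shown alone.

Values in a functional assay on M21 cells (Homo sapiens) for antiproliferative activity, read by sulforhodamine B assay, with a stated time of 48 h (a higher number here means a weaker inhibitor, a lower number a stronger inhibitor), follow here
Compound 1 `CCCN1CCN(c2ccc(S(=O)(=O)Oc3cccc(F)c3)cc2)C1=O` gives 12000 nM as a measured number
Compound 2 `CCCCN1CCN(c2ccc(S(=O)(=O)Oc3ccccc3)cc2)C1=O` gives > 100000 nM as a limit
Compound 3 `CCCCN1CCN(c2ccc(S(=O)(=O)Oc3cccc(F)c3)cc2)C1=O` gives > 100000 nM as a limit

Compound 3 has no number, only the limit > 100000 nM in this test. Its place is the limit of > 100000 nM in this assay, at which 2 of the 3 values shown sit, and no finer ranking is possible. Compound 4 `CCCCN1CCN(c2ccc(S(=O)(=O)Oc3ccc(F)c(F)c3)cc2)C1=O` carries one change (fluoro in place of hydrogen on an aromatic carbon) that turns 3-fluorophenyl to 3,4-difluorophenyl. The nearest measured swap of fluoro for hydrogen (a step that the two limits leave unreadable from compound 2 to compound 3) gives no size. The chain step (an at least 8.3-fold higher number from compound 1 to compound 3 (0.92 log units; beyond the scatter)) was clear but lies elsewhere in the molecule. No step beyond the scatter is therefore expected, and another limit is the likeliest report. An estimated a number no higher from compound 3 to compound 4 (the limit leaves the size open) is expected. The estimate for compound 4 is 100000 nM within an expected range of 40000 nM to 250000 nM overall.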

Compound 4, half-maximal inhibitory concentration: > 100000 nM
Compound 4: only a limit was reported; the forecaster's own chance of this, stated with the estimate: 85%; the middle value sits exactly at the limit.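

Among the compounds shown here, compound 2, compound 3 and compound 4 all report only limits, not numbers, so no step among them can be read. Whether fluoro in place of hydrogen changes the activity of these compounds at all stays open.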